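The compounds below may be only part of what the source reports. "The series", "measured", "known", "first", "only" and "open" are said of these compounds alone.

Compound 1 `CCNc1nc(Cl)nc(N[C@@H](C)c2ccccc2)n1`: 30900 nM
Compound 2 `CCNc1nc(Cl)nc(N[C@H](C)c2ccccc2)n1`: 2690 nM
Compound 3 `CCCN(CC)c1nc(Cl)nc(N[C@@H](C)c2ccccc2)n1`: 282 nM

All three values come from an ADME assay on the whole organism for inhibition, with Echinochloa crus-galli var. formosensis as the target, with a stated time of 4 days; a lower number here means a stronger inhibitor, a higher number a weaker inhibitor. Compound 2 holds the middle place, with a higher number than compound 3 and a lower number than compound 1.

The next compound is compound 4 `CCCN(C)c1nc(Cl)nc(N[C@H](C)c2ccccc2)n1`, which keeps the configuration drawn in compound 2. The change is methyl(propyl)amino in place of ethylamino on an aromatic carbon.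

Among the measured compounds shown here, two measured steps bear on this. For the measured compounds named here, the closer one is a 110-fold lower number from compound 1 to compound 3 (2.04 log units; beyond the scatter), where propyl replaces the hydrogen on that nitrogen, but it was seen only in the other configuration. Compound 3 also retains ethyl where compound 4 has methyl. The second is an 11-fold lower number from compound 1 to compound 2 (1.06 log units; beyond the scatter), which rests on the fact that compounds 1 and 2 differ only in the configuration as drawn and shows that the configuration matters here, so the first step may not carry over in full.

A large drop is therefore expected, somewhat smaller than the first step, in the form of an 18-fold lower number from compound 2 to compound 4 (1.25 log units; beyond the scatter). The estimated value for compound 4 is 150 nM, with an expected range of 25 nM to 1000 nM.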

Compound 4, half-maximal inhibitory concentration: 9770 nM
Compound 4: middle estimate off by 65-fold (1.81 log units), on the low side, and the stated range ends below it.
By their numbers in this assay, from the lowest: compound 3; then compound 2; then compound 4; then compound 1.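

On the configuration drawn in compound 2, replacing ethylamino with methyl(propyl)amino weakens inhibition in this assay, giving a 3.6-fold higher number from compound 2 to compound 4 (0.56 log units; beyond the scatter), whereas the related change on the other configuration gave a 110-fold lower number from compound 1 to compound 3 (2.04 log units; beyond the scatter). A fully substituted nitrogen at this position therefore does not bring a gain on its own, and the size and direction of the change depend on what else differs between the pairs. Those two steps differ both in configuration and in methyl versus ethyl on the nitrogen, and configuration alone already counts in this series, as an 11-fold lower number from compound 1 to compound 2 (1.06 log units; beyond the scatter) rests on one fact: the fact that compounds 1 and 2 differ only in the configuration as drawn.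

The compounds shown do not separate the contribution of configuration from that of the methyl and ethyl groups. From the compounds shown here alone, it also remains open how a dimethylamino or butyl(methyl)amino group would behave at this position on either configuration.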